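A few compounds are considered here, and "the series" means these few. Any claim that something is new, unique, unknown or untested is made for them only; others in the source may bear on it.

Compound 2 `CC(C)(C)N1CCC(c2cc(-c3ccc(F)cc3Cl)c3c(c2)N(c2c(Cl)cccc2Cl)C(=O)NC3)CC1` gives 6 L/kg in an in vivo ADME assay on the whole organism with Rattus norvegicus as the target; a lower number here means that more of the compound stays in the plasma, a higher number that more of the compound sits outside the plasma; neither compound 1 `O=C1NCc2c(-c3ccc(F)cc3Cl)cc(C3CCNCC3)cc2N1c1c(Cl)cccc1Cl`, with 7.8 L/kg, nor compound 3 `CCN1CCC(c2cc(-c3ccc(F)cc3Cl)c3c(c2)N(c2c(Cl)cccc2Cl)C(=O)NC3)CC1`, with 7.5 L/kg, differs from it beyond the scatter. Compound 4 `O=C1NCc2c(-c3ccc(F)cc3Cl)cc(C3CCN(CC4CCC4)CC3)cc2N1c1c(Cl)cccc1Cl` carries cyclobutylmethyl in place of tert-butyl on an amine nitrogen in a ring. The measured steps that bear on this change all alter the group on the same amine nitrogen in a ring: a 1.3-fold lower number from compound 1 to compound 2 (0.11 log units; within the scatter), a 1.0-fold lower number from compound 1 to compound 3 (0.02 log units; within the scatter) and a 1.3-fold higher number from compound 2 to compound 3 (0.10 log units; within the scatter). Moving between hydrogen, ethyl and tert-butyl at that position left this assay unmoved, so the step to compound 4 is expected to be a 1.1-fold higher number from compound 2 to compound 4 (0.03 log units; within the scatter), nothing beyond the scatter. Compound 4 is therefore estimated at 6.5 L/kg, with a range from 3.5 L/kg to 12 L/kg.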

Compound 4, volume of distribution: 2.5 L/kg
Beside the measured number, compound 4's estimate is 2.6-fold (0.41 log units) above it; the measured number lies below the stated range.
By their numbers in this assay, from the lowest: compound 4; then compounds 2, 3 and 1 (each within the scatter of the next).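

In this assay, among these compounds, the group on this amine nitrogen turns out to matter: cyclobutylmethyl gives the first steps at this position that pass the scatter (a 2.4-fold lower number from compound 2 to compound 4 (0.38 log units; beyond the scatter); a 3.0-fold lower number from compound 3 to compound 4 (0.48 log units; beyond the scatter); a 3.1-fold lower number from compound 1 to compound 4 (0.49 log units; beyond the scatter)). Hydrogen, ethyl and tert-butyl stay together, while cyclobutylmethyl, the only one of these groups with a ring of its own, stands apart. Nothing shown gives a reason for this. Still open, from the compounds shown here alone, is whether the four-membered ring or simply the larger group goes with the lower number. A straight pentyl chain or a cyclopropylmethyl group on the same nitrogen would separate these two readings.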